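The compounds below may be only part of what the source reports. "The series", "measured", "known", "first", "only" and "open" are said of these compounds alone.

Compound 1, `CCCCCCCCc1cn([C@H]2C[C@@H]3OP(=O)(O)OC[C@H]3O2)c(=O)[nH]c1=O`: 164 ug/mL
Compound 2, `CCCCc1cn([C@H]2C[C@H](O)[C@@H](CO)O2)c(=O)[nH]c1=O`: > 500 ug/mL

In a functional assay on L1210 cells (Mus musculus) (on this read-out lower numbers stand for stronger inhibition and higher numbers for weaker inhibition), compound 1 gives 164 ug/mL, the only actual number among the two results shown. Compound 2 reaches only > 500 ug/mL, which is a limit of the assay and not a number, so it marks the reading of the limit of > 500 ug/mL in this assay, at which 1 of the 2 values shown sits. For the measured compounds named here, no pair among the measured compounds differs in a single place, so no step size can be read from them.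

Compound 3, `CC(C)c1cn([C@H]2C[C@@H]3OP(=O)(O)OC[C@H]3O2)c(=O)[nH]c1=O`, is not yet measured. It differs from compound 1 in one place: isopropyl in place of octyl on an aromatic carbon. Compound 2, which carries the shortest chain on that carbon among the measured compounds, sits only at the limit, so a shorter chain is expected to go with weaker inhibition. The step of a 2.4-fold higher number from compound 1 to compound 3 (0.39 log units; beyond the scatter) is therefore expected to run toward weaker inhibition, beyond the usual scatter. For compound 3 the estimate is 400 ug/mL, with a range from 150 ug/mL to 1000 ug/mL, and a fair chance that only a limit is reported.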

Compound 3, concentration for 50% inhibition: > 500 ug/mL
Compound 3: a limit, no number; the forecaster's own chance of this, stated with the estimate: 50%; middle value at least 1.2-fold (0.09 log units) away from the limit.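

In this assay, for the compounds shown here, isopropyl in place of octyl on this aromatic carbon gives an at least 3.0-fold higher number from compound 1 to compound 3 (0.48 log units; beyond the scatter), the first change at this position whose size can be read, and it lies beyond the usual scatter. Compound 3 reads > 500 ug/mL, which is a limit and not a number. On the core of compound 1, then, the octyl chain goes with a numerical reading and the isopropyl group does not, and most results now stand at the end of the scale: the limit of > 500 ug/mL in this assay, at which 2 of the 3 values shown sit.

The compounds shown leave open how inhibition changes for chains of intermediate length between isopropyl and octyl, and whether a longer chain such as decyl would lower the number further. They also leave open how an amine or a carboxylic acid at this carbon would read.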